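The compounds below may be only part of what the source reports. "The series", "measured", "known", "first", "only" and "open" are said of these compounds alone.

Measured so far in a functional assay on CHO cells for agonist activity at Alpha-1A adrenergic receptor (Homo sapiens), read by FLIPR and calcium flux; a higher number here means a larger maximal response, a lower number a smaller maximal response:
- compound 1, `Cn1ccc(-c2cccc3c2CCC3c2ncc[nH]2)n1`: 19%
- compound 2, `Clc1ccc2c(c1-c1ccn[nH]1)CCC2c1ncc[nH]1`: 40%

Compound 1 stands at the bottom of these two numbers. Its nearest neighbour, compound 2, reaches a maximal response that lies beyond the usual scatter of this assay, so the two compounds do differ, though neither shows a strong maximal response.

Compound 3, `CCS(=O)(=O)Nc1cccc2c1CCC2c1ncc[nH]1`, has not yet been measured. It differs from compound 1 in one place: (ethylsulfonyl)amino in place of 1-methyl-1H-pyrazol-3-yl on an aromatic carbon. Going by the values given here, no two measured compounds are separated by this kind of exchange, so there is no measured step to lean on, and the direction of the expected step is uncertain. A change of the order seen between the two measured compounds is expected, more likely upward than downward, giving an expected step of a number 16 percentage points higher from compound 1 to compound 3 (beyond the scatter). Compound 3 is therefore estimated to reach 35%, with a range from 10% to 70%.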

Compound 3, largest response reached (Emax), in percent of the reference or control that the assay uses: 86%
The estimate for compound 3 lay 51 percentage points below the measured number; measured number above the stated range.
By their numbers in this assay, from the lowest: compound 1; then compound 2; then compound 3.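

In this assay, putting (ethylsulfonyl)amino in place of 1-methyl-1H-pyrazol-3-yl on this aromatic carbon gives a step of a number 67 percentage points higher from compound 1 to compound 3 (beyond the scatter) and shows that a single exchange at this position can change the maximal response by a large amount. The two groups have the same count of heavy atoms, but the entering group has no ring, contains sulfur and oxygen, and adds a hydrogen-bond donor. No measurement here shows which of these differences matters for the step.

As far as these compounds go, it remains open whether the high response depends on the ethyl chain, which could be tested with methylsulfonylamino or the longer propylsulfonylamino. Replacing the sulfonyl with a carbonyl, as in an acetylamino group, or placing a methyl group on the nitrogen would probe other parts of the entering group.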